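Amide replacements of the terminal carboxylic acid in this series

The source may report more compounds than this note shows. Statements on the series, on what has been measured and on what is new or still open speak of the compounds shown alone.

Compound 1 `O=C(O)CCC(=O)OCCCCCCSc1ccc([N+](=O)[O-])c2nonc12` is the parent acid of the set. In an assay on isolated protein for inhibition of glutathione S-transferase Mu 2 (Homo sapiens), with a stated time of 10 min (on this read-out lower numbers stand for stronger inhibition and higher numbers for weaker inhibition), compound 1 gives 160 nM, the second highest of the three numbers recorded so far. The two amides already measured frame it: compound 2 `O=C(CCC(=O)OCCCCCCSc1ccc([N+](=O)[O-])c2nonc12)Nc1ccccc1Cl` gives 330 nM, while compound 3 `O=C(CCC(=O)OCCCCCCSc1ccc([N+](=O)[O-])c2nonc12)Nc1ccc(C(F)(F)F)cc1` gives 90 nM. The step of a 2.1-fold higher number from compound 1 to compound 2 (0.31 log units; beyond the scatter) is a modest loss and lies beyond the scatter; the step of a 1.8-fold lower number from compound 1 to compound 3 (0.25 log units; within the scatter) runs the other way but stays within the scatter, and between the two amides a 3.7-fold lower number from compound 2 to compound 3 (0.56 log units; beyond the scatter) is again modest.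

Compound 4 `CN(C)CCNC(=O)CCC(=O)OCCCCCCSc1ccc([N+](=O)[O-])c2nonc12` carries the same kind of change at the same carbonyl carbon: (2-(dimethylamino)ethyl)amino in place of hydroxy on a carbonyl carbon. Both measured amide steps bear on it, and together they show that converting the hydroxy to an amide moves the number only a little in either direction. Nothing in the data singles out the (2-(dimethylamino)ethyl)amino group, so no step beyond the scatter is expected; the estimate for compound 4 is 200 nM, with a range from 80 nM to 500 nM, corresponding to an expected step of a 1.3-fold higher number from compound 1 to compound 4 (0.10 log units; within the scatter).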

Compound 4, half-maximal inhibitory concentration: 160 nM
Compound 4: the middle estimate sits 1.3-fold (0.10 log units) above what was measured, within the range that was stated.
By their numbers in this assay, from the lowest: compounds 3, 1 and 4 (each within the scatter of the next); then compound 2.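

In this assay, the step to the (2-(dimethylamino)ethyl)amino group shows no change at the digits printed from compound 1 to compound 4 (within the scatter), so this carbonyl carbon accepts an amide bearing an amine chain as well as the two aryl amides, with no measurable cost from replacing hydroxy with this larger group of 6 heavy atoms. Among the amides, a 1.8-fold higher number from compound 3 to compound 4 (0.25 log units; within the scatter), so the 2-(dimethylamino)ethyl and 4-(trifluoromethyl)phenyl groups cannot be told apart, whereas a 2.1-fold lower number from compound 2 to compound 4 (0.31 log units; beyond the scatter) leaves the 2-chlorophenyl amide, compound 2, as the only one of the four set apart beyond the scatter, with the highest number. No supporting measurement bears on this result.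

Still open, as far as these compounds go, is whether a longer chain before the dimethylamino group, or a morpholine in its place, would hold this level. A carboxylic acid at the end of the amide chain is equally untested in the compounds shown here.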